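Swapping an oxane for a methylpiperazine on the sulfonyl group

A few compounds are considered here, and "the series" means these few. Any claim that something is new, unique, unknown or untested is made for them only; others in the source may bear on it.

Of the compounds shown here, three built on one shared core have been tested in a physicochemical assay for solubility, in phosphate buffer, with a stated time of 24 h, at pH 7.4, tested at 100 uM; on this read-out higher numbers stand for higher solubility and lower numbers for lower solubility. Compound 1 `CC(C)n1cc(S(=O)(=O)c2ccc(CNC(=O)N3Cc4ccncc4C3)cc2)cn1` gives 192000 nM, compound 2 `O=C(NCc1ccc(S(=O)(=O)C2CCC(F)(F)CC2)cc1)N1Cc2ccncc2C1` gives 35000 nM, and compound 3 `O=C(NCc1ccc(S(=O)(=O)C2CCOCC2)cc1)N1Cc2ccncc2C1` gives 206000 nM. Compound 3 and compound 1 lie within the scatter of each other (a 1.1-fold higher number from compound 1 to compound 3 (0.03 log units; within the scatter)), while compound 3 stands clearly beyond compound 2 (a 5.9-fold higher number from compound 2 to compound 3 (0.77 log units; beyond the scatter)), matching the drop seen in a 5.5-fold lower number from compound 1 to compound 2 (0.74 log units; beyond the scatter). Compound 4 `CN1CCN(S(=O)(=O)c2ccc(CNC(=O)N3Cc4ccncc4C3)cc2)CC1` differs from compound 3 in one place: 4-methylpiperazin-1-yl in place of oxan-4-yl on a sulfonyl sulfur. For the measured compounds named here, no measured step involves a ring with two hetero atoms at this position, so the only guide is that earlier swaps here moved this assay by little or modestly. The step of a 1.1-fold higher number from compound 3 to compound 4 (0.03 log units; within the scatter) is expected to stay within the scatter. Compound 4 is estimated at 220000 nM, with a range from 110000 nM to 420000 nM.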

Compound 4, solubility: 160000 nM
The estimate for compound 4 lay 1.4-fold (0.14 log units) above the measured number; measured number inside the range.
By their numbers in this assay, from the lowest: compound 2; then compounds 4, 1 and 3 (each within the scatter of the next).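

In this assay, 4-methylpiperazin-1-yl, the only non-aromatic ring here with 2 hetero atoms, gives a number within the scatter of oxan-4-yl (a 1.3-fold lower number from compound 3 to compound 4 (0.11 log units; within the scatter)) and of 1-isopropyl-1H-pyrazol-4-yl (a 1.2-fold lower number from compound 1 to compound 4 (0.08 log units; within the scatter)). For the compounds shown here, that leaves 4,4-difluorocyclohexyl as the one group of the four standing apart (a 4.6-fold higher number from compound 2 to compound 4 (0.66 log units; beyond the scatter)). Nothing available explains why these three rings read alike.

Still open, going by these compounds, is whether an open chain, such as a simple butyl group, would stay with those three rings or fall toward the difluorocyclohexyl compound. The same question applies to a carboxylic acid carried on the ring at the sulfonyl sulfur.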